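Three Anilino-Thiazole Chalcones That Stay Outside the Measurable Range

A few compounds are considered here, and "the series" means these few. Any claim that something is new, unique, unknown or untested is made for them only; others in the source may bear on it.

The series was examined in a functional assay on Bel-7402 cells (Homo sapiens) for cytotoxicity, read by MTT assay; on this read-out higher numbers stand for weaker inhibition and lower numbers for stronger inhibition. Compound 1, `COc1cccc(/C=C/C(=O)c2sc(Nc3cccc(C)c3)nc2C)c1`, gives only a limit of the assay and no number in this assay, > 25000 nM. Compound 2, `COc1cccc(/C=C/C(=O)c2sc(Nc3ccccc3)nc2C)c1`, likewise gives only a limit in this assay, > 25000 nM. Compound 3, `Cc1cccc(Nc2nc(C)c(C(=O)/C=C/c3ccccc3)s2)c1`, also gives only a limit in this assay, > 25000 nM.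

Two single changes connect these three compounds. From compound 1 to compound 2 the change is hydrogen in place of methyl on an aromatic carbon, and the two limits leave the step that the two limits leave unreadable from compound 1 to compound 2 unreadable. From compound 1 to compound 3 the change is hydrogen in place of methoxy on an aromatic carbon, and here too the step that the two limits leave unreadable from compound 1 to compound 3 cannot be read, because all three values sit at the limit of > 25000 nM in this assay, at which 3 of the 3 values shown sit.

Compound 4, `Cc1nc(Nc2ccccc2)sc1C(=O)/C=C/c1ccccc1`, has not yet been measured in this assay. It differs from compound 3 by hydrogen in place of methyl on an aromatic carbon, which is the same change already made from compound 1 to compound 2, in the same place; the cores of compound 3 and compound 1 differ by hydrogen in place of methoxy on an aromatic carbon.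

For compound 4 the step that the limit leaves unreadable from compound 3 to compound 4 from compound 3 is expected to be unreadable as well, resting on the fact that compound 1, compound 2 and compound 3 all sit at the limit of > 25000 nM in this assay, at which 3 of the 3 values shown sit. Compound 4 is therefore estimated at 40000 nM, between 20000 nM and 120000 nM, most likely reported only as a limit.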

Compound 4, half-maximal inhibitory concentration: > 25000 nM
Compound 4: only a limit was reported; the forecaster's own chance of this, stated with the estimate: 85%; the middle value does not contradict the limit.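

In this assay compound 4 gives > 25000 nM as a limit and not as a number. No new step can be read from compound 3 to compound 4 or from compound 2 to compound 4, because all the values stand at one limit: the limit of > 25000 nM in this assay, at which 4 of the 4 values shown sit. The compounds shown leave open how far each of the four lies beyond that limit, and whether any change to the shared core would give a measurable value.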